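The compounds below may be only part of what the source reports. "The series", "measured", "known", "first", "only" and "open" are said of these compounds alone.

Compound 1 `CC(=O)c1ccc(OCCCCC#N)cc1O` gives 0% in an assay on isolated protein for binding affinity to leukotriene B4 receptor 1 (Homo sapiens), tested at 1 uM; a higher number here means more inhibition at the concentration tested (going by the name of the read-out), a lower number less inhibition. Compound 2 `CC(=O)c1cc(C)c(OCCCCC#N)cc1O` gives 35%, and compound 3 `CCc1cc(C(C)=O)c(O)cc1OCCCCC#N` gives 57% in this assay. Compound 3 stands highest of the three numbers; compound 2 is its nearest neighbour and compound 1 lies furthest below. Two steps were large, and each adds an alkyl group where compound 1 carries hydrogen: a number 35 percentage points higher from compound 1 to compound 2 (beyond the scatter) and a number 57 percentage points higher from compound 1 to compound 3 (beyond the scatter). The third step, a number 22 percentage points higher from compound 2 to compound 3 (beyond the scatter), added a carbon to that group and was modest.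

Compound 4 `CCCc1cc(C(C)=O)c(O)cc1OCCCCC#N` carries the change (methyl in place of hydrogen on a saturated chain carbon, two bonds along the chain from an aromatic carbon). The step that bears most directly on it is a number 22 percentage points higher from compound 2 to compound 3 (beyond the scatter), since it too extends the chain by one carbon; the two large steps concern the first carbon on the aromatic carbon and are less comparable. A small rise in this assay, or none beyond the scatter, is therefore expected. Compound 4 is expected at 65%, with a range of 45% to 85%. The expected step is a number 8 percentage points higher from compound 3 to compound 4 (within the scatter).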

Compound 4, a percentage reported as inhibition, at one concentration (the size of the read-out at that concentration, not a potency): 37%
For compound 4 the middle estimate is 28 percentage points above the measured one, and the stated range ends above it.
By their numbers in this assay, from the lowest: compound 1; then compounds 2 and 4 (each within the scatter of the next); then compound 3.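

Lengthening the alkyl group at this aromatic position does not keep raising the inhibition read-out in this assay: going from ethyl to propyl reverses the earlier gain (a number 20 percentage points lower from compound 3 to compound 4 (beyond the scatter)), so among the compounds shown the ethyl group of compound 3 gives the highest number. The propyl group gives a read-out that cannot be told apart from that of the methyl group (a number 2 percentage points higher from compound 2 to compound 4 (within the scatter)), yet it still retains a clear gain over hydrogen (a number 37 percentage points higher from compound 1 to compound 4 (beyond the scatter)). Nothing available accounts for the drop from ethyl to propyl.

Going by these compounds, it remains open whether a butyl group would lower the number further, or whether a branched isopropyl group would behave like ethyl or like propyl. On these data alone, these are readings at a single concentration, so the order of the compounds by potency also remains open.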